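The source may report more compounds than this note shows. Statements on the series, on what has been measured and on what is new or still open speak of the compounds shown alone.

Measured so far in an assay on Sf9 cells for inhibition of histone deacetylase 11 (Homo sapiens), read by fluorescence, tested at 0.5 uM; a lower number here means less inhibition, a higher number more inhibition at the concentration tested (going by the name of the read-out): compound 1 `O=C(/C=C/c1cn([C@@H]2C[C@@H](C(=O)O)N(Cc3ccccc3)C2)nn1)NO` gives 12%; compound 2 `O=C(/C=C/c1cn([C@H]2C[C@@H](C(=O)O)N(CCCc3ccccc3)C2)nn1)NO` gives 29%; compound 3 `O=C(/C=C/c1cn([C@H]2C[C@H](C(=O)O)N(Cc3ccccc3)C2)nn1)NO` gives 14%.

Compound 3 stands in the middle of the three numbers, indistinguishable from compound 1 and clearly below compound 2. The next compound, compound 4 `O=C(/C=C/c1cn([C@H]2C[C@@H](C(=O)O)N(Cc3ccccc3)C2)nn1)NO`, keeps every atom and bond of compound 3; the change is the two compounds have the same atoms and bonds and differ only in configuration as drawn: 1 of 3 stereo elements differ; a stereocentre at a saturated ring carbon is drawn R in compound 3 and S in compound 4. Going by the values given here, only one measured step bears on a change of this kind, namely a number 2 percentage points higher from compound 1 to compound 3 (within the scatter), which stayed within the scatter because of the fact that compounds 1 and 3 differ only in the configuration as drawn. Among the compounds with values here, compound 2 shares the drawn configuration of compound 4 but differs from it elsewhere, so its value alone shows no separate step. A step within the scatter is therefore expected, a number 2 percentage points higher from compound 3 to compound 4 (within the scatter). Compound 4 is estimated at 16%, in the range 6% to 28%.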

Compound 4, a percentage reported as inhibition, at one concentration (the size of the read-out at that concentration, not a potency): 23%
Compound 4: the middle estimate sits 7 percentage points below what was measured; low and high end bracket the measured number.
By their numbers in this assay, from the lowest: compounds 1, 3, 4 and 2 (each within the scatter of the next, the first and the last beyond it).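

In this assay, going by these compounds alone, inverting a single stereocentre at a saturated ring carbon gives a number 11 percentage points higher from compound 1 to compound 4 (beyond the scatter), the first configuration step to pass the scatter, and it can be put down to stereochemistry alone: the fact that compounds 1 and 4 differ only in the configuration as drawn. The inversion at the other ring carbon gives a number 9 percentage points higher from compound 3 to compound 4 (within the scatter), so not every such inversion clearly registers. With this configuration, phenyl in place of phenethyl on the chain at the ring amine nitrogen gives a number 6 percentage points lower from compound 2 to compound 4 (within the scatter).

Still open, from the compounds shown here alone, is how a methyl ester in place of the carboxylic acid would read in this assay. A longer chain on the ring amine nitrogen is equally untested by these compounds.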